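Three Measured Compounds and One Change Still to Test

The source may hold more compounds than are shown below. What is called first, only, known or untested is meant among the compounds shown, and "the series" means these compounds.

Of the compounds shown here, three have been measured in an assay on isolated protein for inhibition of Rho-associated protein kinase 2 (Homo sapiens), read by scintillation counting, radiometric assay and 33P incorporation, with a stated time of 40 min, in the presence of a further agent that is not named here; a lower number here means a stronger inhibitor, a higher number a weaker inhibitor. Compound 1 `CC(=O)c1ccc(OCC(=O)Nc2cccc(NC(=O)c3ccc(N(C)C)cc3)c2)cc1F` gives 98 nM. Compound 2 `Cc1c(OCC(=O)Nc2cccc(NC(=O)c3ccc(N(C)C)cc3)c2)ccc2c(=O)ccoc12` gives 4160 nM. Compound 3 `Cc1ccc(C(=O)Nc2cccc(NC(=O)COc3ccc4c(=O)ccoc4c3)c2)cc1` gives 22 nM, the lowest of the three numbers; its gap to compound 1 and its gap to compound 2 both lie beyond the usual scatter, so compound 3 is the strongest inhibitor of this set.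

The next compound, compound 4 `CC(C)(C)c1cc(C(=O)Nc2cccc(NC(=O)COc3ccc4c(=O)ccoc4c3)c2)no1`, differs from compound 3 in one place: 5-(tert-butyl)-1,2-oxazol-3-yl in place of 4-methylphenyl on a carbonyl carbon. For the measured compounds named here, no pair of measured compounds shows this particular change, so its effect in this assay cannot be read off from earlier results and can only be guessed.

Because compound 3 stands at 22 nM, compound 4 is expected to stay in the same neighbourhood, with a small rise in the number that may well fall within the scatter. The estimated step in this assay is a 2.7-fold higher number from compound 3 to compound 4 (0.44 log units; beyond the scatter). Compound 4 is estimated at 60 nM, within a range from 15 nM to 250 nM.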

Compound 4, half-maximal inhibitory concentration: 5 nM
For compound 4 the middle estimate is 12-fold (1.08 log units) above the measured one, outside the stated range (below it).
By their numbers in this assay, from the lowest: compound 4; then compound 3; then compound 1; then compound 2.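

In this assay, for the compounds shown here, this is the first comparison in the set between two compounds that differ in only one place, and it gives a 4.4-fold lower number from compound 3 to compound 4 (0.64 log units; beyond the scatter). The 4-methylphenyl group is therefore not required on this carbonyl carbon: a five-membered aromatic ring with 2 hetero atoms, carrying a tert-butyl group, is not only accepted but gives the lower number. Nothing measured here explains this drop.

The swap changes the ring and its substituent together, so the compounds shown cannot tell which of the two accounts for the step. A 5-methyl-1,2-oxazol-3-yl group or a 4-(tert-butyl)phenyl group on the same carbonyl carbon would separate the two, and a single comparison cannot show whether the step would carry over to other cores.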